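The source may hold more compounds than are shown below. What is called first, only, known or untested is meant among the compounds shown, and "the series" means these compounds.

Measured so far in an ADME assay on MT2 cells (Homo sapiens) for cytotoxicity; a higher number here means that more compound is tolerated, a lower number that less compound is tolerated:
compound 1 `COc1ccnc(Nc2ccc(Cl)c(OCC=C(C)C)c2)n1` gives 9000 nM
compound 2 `CNc1ccnc(Nc2ccc(Cl)c(OCC=C(C)C)c2)n1` gives 690 nM
compound 3 `COc1cc(N)nc(Nc2ccc(Cl)c(OCC=C(C)C)c2)n1` gives 19000 nM

Compound 1 stands second highest of the three. Its nearest neighbour is compound 3, a 2.1-fold higher number from compound 1 to compound 3 (0.32 log units; beyond the scatter); its furthest is compound 2, a 13-fold lower number from compound 1 to compound 2 (1.12 log units; beyond the scatter). Both of these steps alter the shared core of compound 1 and leave the group on the oxygen untouched.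

Compound 4 `COc1ccnc(Nc2ccc(Cl)c(Oc3ccccc3C)c2)n1` differs from compound 1 at that oxygen instead: 2-methylphenyl in place of 3-methylbut-2-en-1-yl on an oxygen on an aromatic ring. Neither measured step bears on this part of the structure, so nothing in the series gives a direct reading on exchanging a 3-methylbut-2-en-1-yl for a 2-methylphenyl on an oxygen on an aromatic ring. For the measured compounds named here, with no comparable step available, the expectation is for no change beyond the scatter. For compound 4 the expected step is no change at the digits printed from compound 1 to compound 4 (within the scatter). From the compounds shown here alone, the estimate for compound 4 in this assay is 9000 nM, with a wide range of 2500 nM to 30000 nM; the width states plainly that this side of the molecule is unexplored in the measured set.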

Compound 4, half-maximal cytotoxic concentration: 13000 nM
Beside the measured number, compound 4's estimate is 1.4-fold (0.16 log units) below it, within the range that was stated.
By their numbers in this assay, from the lowest: compound 2; then compounds 1, 4 and 3 (each within the scatter of the next, the first and the last beyond it).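

In this assay, for the compounds shown here, the first reading at the oxygen on an aromatic ring is a 1.4-fold higher number from compound 1 to compound 4 (0.16 log units; within the scatter), so the two compounds cannot be told apart, although 2-methylphenyl brings an aromatic ring and more heavy atoms in place of the open chain of 3-methylbut-2-en-1-yl. Among the steps shown, the large one remains on the shared core, a 13-fold lower number from compound 1 to compound 2 (1.12 log units; beyond the scatter), while this first change at the oxygen stays within the scatter. No measurement on hand offers a reason for this result.

A single exchange cannot say whether phenyl, a longer chain or a chain ending in an amine on the same oxygen would also stay level with compound 1. From the compounds shown here alone, it also remains open whether methylamino in place of methoxy on the shared core would give a similar step with 2-methylphenyl on the oxygen.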